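Chloro on the Fused Ring: Expecting Compound 4

This account rests on a few compounds, and the source may have more. Where it says the series, first, only, none or still open, it means among the compounds named here.

Measured compounds:
- compound 1, `Cc1cc(-c2nc3cc(Cl)ccc3o2)ccc1NC(=O)CN1CCN(CCN(C)C)CC1`, 24400 nM
- compound 2, `Cc1cc(-c2nc3ccccc3o2)ccc1NC(=O)CN1CCN(CCN(C)C)CC1`, 30500 nM
- compound 3, `Cc1cc(-c2nc3ccccc3o2)ccc1NC(=O)CCl`, 33500 nM

All three were tested in a functional assay on A549 cells (Homo sapiens) for cytotoxicity, read by MTT assay, with a stated time of 24 h; a higher number here means a weaker inhibitor, a lower number a stronger inhibitor. In this assay compound 1 gives 24400 nM, compound 2 gives 30500 nM and compound 3 gives 33500 nM. The three numbers lie within the usual scatter of one another, so no one of them can be called stronger or weaker than the others.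

Compound 4, `Cc1cc(-c2nc3cc(Cl)ccc3o2)ccc1NC(=O)CCl`, has not yet been measured. It is related to compound 3 by a single change, (chloro in place of hydrogen on an aromatic carbon). The same change is already seen once among the measured compounds, going from compound 2 to compound 1: chloro in place of hydrogen on an aromatic carbon. That change gave a 1.3-fold lower number from compound 2 to compound 1 (0.10 log units; within the scatter), a step too small to be told apart from repeat measurements. The place of the change is described in the same words in both cases, so it is the same change, made on two different cores. The difference between the core of compound 3 and the core of compound 2 is not broken down here.

Going by the values given here, for compound 4 the step from compound 3 is expected to be of the same modest size, a 1.3-fold lower number from compound 3 to compound 4 (0.11 log units; within the scatter), because the only example of this change, a 1.3-fold lower number from compound 2 to compound 1 (0.10 log units; within the scatter), stayed within the scatter. Compound 4 is therefore estimated at 26000 nM, with a likely range from 13000 nM to 55000 nM.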

Compound 4, half-maximal inhibitory concentration: 91500 nM
Estimate against measurement, compound 4: 3.5-fold (0.55 log units) below, outside the stated range (above it).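

In this assay, chloro in place of hydrogen on an aromatic carbon gives a 2.7-fold higher number from compound 3 to compound 4 (0.44 log units; beyond the scatter), so on this core the change leaves compound 4 a weaker inhibitor than compound 3, a step beyond the usual scatter. Set beside the earlier step, the same change does not carry over unchanged from one core to the other, so a step measured on one core is not a safe guide to its size or direction on the other: the same change on two cores in this assay, a 1.3-fold lower number (0.10 log units; within the scatter) from compound 2 to compound 1 and a 2.7-fold higher number (0.44 log units; beyond the scatter) from compound 3 to compound 4, 3.4-fold (0.53 log units) apart, beyond the scatter of two such steps. Going by these compounds alone, this rests on only two pairs of compounds, so it shows that the core can matter but not which part of the core is responsible, why the two steps part ways, or how the change would behave on any third core.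

The compounds shown leave open whether a fluoro or a methoxy group on the same aromatic carbon would also give different steps on the two cores, or whether this split belongs to chloro alone. They also leave open where a core ending in a simple amine, such as a dimethylamino group joined directly to the acetamide chain, would fall between the two results.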